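The source may hold more compounds than are shown below. What is called first, only, known or untested is meant among the compounds shown, and "the series" means these compounds.

Of the compounds shown here, three built on a shared core have been tested in a functional assay on BaF3 cells (Mus musculus) for antiproliferative activity, read by CCK-8 assay and cell counting, with a stated time of 76 h; a lower number here means a stronger inhibitor, a higher number a weaker inhibitor. Compound 1 `COc1cc2nccc(Oc3ccc(Nc4nn(C)cc4C(=O)Nc4cccc(F)c4)cc3)c2cc1C(N)=O` gives 4480 nM in this assay. Compound 2 `COc1cc2nccc(Oc3ccc(Nc4nn(C)cc4C(=O)N4CCCCC4)cc3)c2cc1C(N)=O` gives 5650 nM. Compound 3 `COc1cc2nccc(Oc3ccc(Nc4nn(C)cc4C(=O)Nc4ccccc4)cc3)c2cc1C(N)=O` reaches only the limit of the assay, > 10000 nM, so for compound 3 no number is known, only that it sits at that limit (the limit of > 10000 nM in this assay, at which 1 of the 3 values shown sits). The measured steps between them are a 1.3-fold higher number from compound 1 to compound 2 (0.10 log units; within the scatter), an at least 2.2-fold higher number from compound 1 to compound 3 (0.34 log units; beyond the scatter) and an at least 1.7-fold higher number from compound 2 to compound 3 (0.24 log units; that floor lies within the scatter).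

Compound 4 `COc1cc2nccc(Oc3ccc(Nc4nn(C)cc4C(=O)NC45CCC(CC4)CC5)cc3)c2cc1C(N)=O` differs from compound 3 in a single place: a group of 8 heavy atoms (8 carbon; 2 six-membered non-aromatic rings of carbon only) in place of a group of 6 heavy atoms (6 carbon; one six-membered aromatic ring of carbon only), on an amide-type nitrogen. The step that bears most directly on this change is an at least 1.7-fold higher number from compound 2 to compound 3 (0.24 log units; that floor lies within the scatter), in which anilino took the place of piperidin-1-yl on the carbonyl carbon and the number rose from a measured value to a limit. Compound 4 returns a non-aromatic group to the amide-type nitrogen, so the number is expected to move back downward, toward the region where compound 2 stands, although with compound 3 known only as a limit the size of that step cannot be pinned down, and a second limit remains possible. The expected step is an at least 1.2-fold lower number from compound 3 to compound 4 (0.09 log units; that floor lies within the scatter). Compound 4 is therefore estimated at 8000 nM in this assay, with a range from 3000 nM to 20000 nM.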

Compound 4, half-maximal inhibitory concentration: > 10000 nM
Compound 4: only a limit was reported (the forecaster's own chance of this, stated with the estimate: 40%); at least 1.2-fold (0.09 log units) between middle value and limit.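

In this assay compound 4 also sits at a limit, > 10000 nM, which is a boundary of the assay and not a number. This shows what compound 2 and compound 3 alone could not: putting a non-aromatic group in place of phenyl on the amide-type nitrogen does not by itself bring the result back into the measurable range, at least not with this group of two non-aromatic rings. Against the measured compounds, the result is an at least 1.7-fold higher number from compound 2 to compound 4 (0.24 log units; that floor lies within the scatter) and an at least 2.2-fold higher number from compound 1 to compound 4 (0.34 log units; beyond the scatter), so only the second of these floors clears the usual scatter, and compound 2 cannot be firmly separated from compound 4.

As far as these compounds go, how far compound 3 and compound 4 lie past the limit remains unknown, so the step between them cannot be read: the limit of > 10000 nM in this assay, at which 2 of the 4 values shown sit. Also open is whether a smaller non-aromatic group on the amide-type nitrogen, such as plain cyclohexyl, or a morpholine ring on the carbonyl carbon in place of piperidin-1-yl, would give a measured number.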